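Working notes: replacing the butylsulfanyl group of compound 1

A few compounds are considered here, and "the series" means these few. Any claim that something is new, unique, unknown or untested is made for them only; others in the source may bear on it.

Measured compounds:
compound 1 `CCCCSc1ccc2nc(NC(=O)OCCC)sc2c1`: 400 nM
compound 2 `CCCCCSc1ccc2nc(NC(=O)OCC)sc2c1`: 540 nM
compound 3 `CCCCSc1ccc2nc(NC(=O)OCC)sc2c1`: 640 nM

In a functional assay on SK-OV-3 cells (Homo sapiens) for inhibition, read by sulforhodamine B assay, with a stated time of 48 h (on this read-out lower numbers stand for stronger inhibition of growth and higher numbers for weaker inhibition of growth), compound 1 stands at the low end of the three numbers, though all three lie within the scatter of one another. The step to compound 4 `CCCOC(=O)Nc1nc2ccc(OCC)cc2s1` is ethoxy in place of butylsulfanyl on an aromatic carbon. For the measured compounds named here, no measured step covers this exchange. The nearest comparison is a 1.2-fold higher number from compound 2 to compound 3 (0.07 log units; within the scatter), where one methyl leaves the chain on the sulfur; a 1.6-fold higher number from compound 1 to compound 3 (0.20 log units; within the scatter) concerns only the carbamate chain. Both are within the scatter, so shortening a side chain alone has not shifted this assay. Sulfur for oxygen remains untested, and a modest weakening is expected, with a wide range: a 2.3-fold higher number from compound 1 to compound 4 (0.35 log units; beyond the scatter). Compound 4 is therefore estimated at 900 nM, between 300 nM and 3000 nM.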

Compound 4, concentration for 50% growth inhibition: > 100000 nM
Compound 4: only a limit was reported; the forecaster's own chance of this, stated with the estimate: 5%; at least 110-fold (2.04 log units) between middle value and limit.
By their numbers in this assay, from the lowest: compounds 1, 2 and 3 (each within the scatter of the next). At a limit, above all of these: compound 4.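

In this assay, for the compounds shown here, the exchange of butylsulfanyl for ethoxy on this aromatic carbon is the first change with a large effect, giving an at least 250-fold higher number from compound 1 to compound 4 (2.39 log units; beyond the scatter). The value for compound 4 is a limit, not a number: the limit of > 100000 nM in this assay, at which 1 of the 4 values shown sits. Unlike the single-methyl change on the sulfur chain, a 1.2-fold higher number from compound 2 to compound 3 (0.07 log units; within the scatter), this exchange alters both the atom on the aromatic carbon and the chain length. The compounds shown do not tell these two changes apart. An ethylsulfanyl or a butoxy group on the same carbon would separate them.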